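Series notes: benzylamine aryl swap on the shared core

A few compounds are considered here, and "the series" means these few. Any claim that something is new, unique, unknown or untested is made for them only; others in the source may bear on it.

For the measured compounds named here, compound 1 `COc1ccc(Oc2ccc3c(NCCCNCc4cc(F)ccc4OC)ccnc3c2)cc1` and compound 2 `COc1ccc(F)cc1CNCCCNc1ccnc2cc(Oc3ccc(F)cc3)ccc12` are the two measured members. In an ADME assay on HepG2 cells (Homo sapiens) for cytotoxicity, read by luminescence, CellTiter-Glo and ATP content, with a stated time of 72 h (a higher number here means that more compound is needed for the effect, a lower number that less compound is needed), compound 1 gives 7000 nM, and compound 2 gives 6600 nM; the two numbers lie within the scatter of each other, the step being a 1.1-fold lower number from compound 1 to compound 2 (0.03 log units; within the scatter) for fluoro in place of methoxy on an aromatic carbon. Compound 3 `COc1ccc(Oc2ccc3c(NCCCNCc4cccc(OC)c4O)ccnc3c2)cc1` differs from compound 1 by 2-hydroxy-3-methoxyphenyl in place of 5-fluoro-2-methoxyphenyl on a saturated chain carbon bound to an amine nitrogen. Going by the values given here, no measured step covers this change; the only measured step shows a substituent swap on that ring leaving this assay unchanged. Compound 3 is therefore expected to show no change at the digits printed from compound 1 to compound 3 (within the scatter), an estimated 7000 nM with a range from 3000 nM to 16000 nM.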

Compound 3, half-maximal effective concentration: 5500 nM
Compound 3: the middle estimate sits 1.3-fold (0.10 log units) above what was measured; low and high end bracket the measured number.
By their numbers in this assay, from the lowest: compounds 3, 2 and 1 (each within the scatter of the next).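

Putting 2-hydroxy-3-methoxyphenyl in place of 5-fluoro-2-methoxyphenyl on a saturated chain carbon bound to an amine nitrogen gives, in this assay, a 1.3-fold lower number from compound 1 to compound 3 (0.10 log units; within the scatter). This step swaps the aryl group's fluorine for a hydroxyl, bringing in a hydrogen-bond donor, and the number stays within the scatter. No available evidence bears on this result.

Still open, on these data alone, is whether a carboxylic acid or a morpholine on this aryl group would move the number in this assay beyond the scatter. The same holds for a cyclohexyl group in place of the aryl ring.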